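Working notes: isopropoxy to (methylsulfonyl)oxy on compound 1

This account rests on a few compounds, and the source may have more. Where it says the series, first, only, none or still open, it means among the compounds named here.

- compound 1 (`CC(C)Oc1cc(-c2ccccc2)nc2ccccc12`) gives > 10 ug/mL
- compound 2 (`COc1ccc2nc(-c3ccccc3)cc(O)c2c1`) gives 0.06 ug/mL

In a functional assay on L1210 (1565) cells (Mus musculus) for cytotoxicity (a lower number here means that less compound is needed, a higher number that more compound is needed for the effect), compound 1 stands at > 10 ug/mL, which is a limit of the assay and not a number. For the measured compounds named here, compound 2 reads 0.06 ug/mL, but no single-place step links it to compound 1, so it sets no size for the change followed here. Compound 3 (`CS(=O)(=O)Oc1cc(-c2ccccc2)nc2ccccc12`) carries methylsulfonyl in place of isopropyl on an oxygen on an aromatic ring. Going by the values given here, no measured step covers this change in this assay. The expectation rests on the limit of compound 1 at > 10 ug/mL alone. The expected change is a number no higher from compound 1 to compound 3 (the limit leaves the size open), with no step beyond the scatter and no firm direction anticipated. For compound 3 the estimated value is 10 ug/mL, with an expected range of 2 ug/mL to 40 ug/mL, and the assay may well report only a limit again.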

Compound 3, half-maximal effective concentration: 6.04 ug/mL
Compound 3: middle estimate off by 1.7-fold (0.22 log units), on the high side; the measured number falls inside the stated range.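

Compound 1 stands at > 10 ug/mL in this assay, and that value is a limit of the assay. With methylsulfonyl in place of isopropyl on the oxygen on the aromatic ring, compound 3 gives 6.04 ug/mL, so this position now carries a real number in the series rather than a limit. The change reads as an at least 1.6-fold lower number from compound 1 to compound 3 (0.21 log units; that floor lies within the scatter), and only a floor can be stated for its size, with the upper end left unbounded: the limit of > 10 ug/mL in this assay, at which 1 of the 3 values shown sits.

As far as these compounds go, whether the true step lies beyond the usual scatter remains open, as does how far it extends. Also open, from the compounds shown here alone, is whether the readable value is particular to methylsulfonyl, or whether an amine or a longer chain on this same oxygen would read similarly in this assay.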